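Swapping the Aryl Group on the Thiourea Nitrogen

The source may report more compounds than this note shows. Statements on the series, on what has been measured and on what is new or still open speak of the compounds shown alone.

Compound 1 `NC(=O)c1c(NC(=O)c2ccccc2Cl)sc2c1CCN(C(=S)Nc1ccccc1F)C2` gives 28700 nM in a functional assay on HeLa cells (Homo sapiens) for antiproliferative activity, with a stated time of 24 h; a higher number here means a weaker inhibitor, a lower number a stronger inhibitor. Compound 2 `COc1ccccc1NC(=S)N1CCc2c(sc(NC(=O)c3ccccc3Cl)c2C(N)=O)C1` gives only a limit in this assay, > 50000 nM, so compound 2 sits at the limit of > 50000 nM in this assay, at which 1 of the 2 values shown sits, and its true position is not pinned down. Going by the values given here, the one measured step, an at least 1.7-fold higher number from compound 1 to compound 2 (0.24 log units; that floor lies within the scatter), concerns a different substituent on the same ring. Compound 3 `NC(=O)c1c(NC(=O)c2ccccc2Cl)sc2c1CCN(C(=S)Nc1ccc(C(F)(F)F)cc1)C2` differs from compound 2 by 4-(trifluoromethyl)phenyl in place of 2-methoxyphenyl on an amide-type nitrogen. Among the compounds with values here, no measured step covers a trifluoromethyl group, so the expected step from compound 2 to compound 3 is an at least 1.2-fold lower number from compound 2 to compound 3 (0.09 log units; that floor lies within the scatter), staying near the limit. The estimate for compound 3 is 40000 nM, ranging from 10000 nM to 150000 nM.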

Compound 3, half-maximal inhibitory concentration: > 50000 nM
Compound 3: only a limit was reported; the forecaster's own chance of this, stated with the estimate: 45%; middle value at least 1.2-fold (0.09 log units) from the limit.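

In this assay, a second replacement on the amide-type nitrogen also ends at a limit rather than a number: the limit of > 50000 nM in this assay, at which 2 of the 3 values shown sit.

Replacing 2-fluorophenyl with 4-(trifluoromethyl)phenyl gives an at least 1.7-fold higher number from compound 1 to compound 3 (0.24 log units; that floor lies within the scatter), so compound 1 remains the only one here with an exact value. The step between the two limits cannot be read, so 2-methoxyphenyl and 4-(trifluoromethyl)phenyl cannot be ranked against each other.

Going by these compounds, it remains open whether any change at this nitrogen gives a lower number than compound 1. On these data alone, a phenyl ring carrying an amine or a carboxylic acid, or a longer chain in place of the ring, also remains open.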